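Carboxymethyl extension on the glycine carbon of compound 2

This account rests on a few compounds, and the source may have more. Where it says the series, first, only, none or still open, it means among the compounds named here.

Measured compounds:
compound 1, `O=C(CN(c1nc(Cl)nc2[nH]cnc12)C1CC1)NCC(=O)OCc1ccccc1` — 18%
compound 2, `O=C(O)CNC(=O)CN(c1nc(Cl)nc2[nH]cnc12)C1CC1` — 9.08%

In a functional assay on the whole organism (Tail, strain ICR) with Mus musculus as the target, in the tail flick test, with a stated time of 150 min, at a dose of 25 umol/kg by the oral route (a higher number here means a stronger effect of the compound at the dose given, a lower number a weaker effect), compound 1 gives 18%, and compound 2 gives 9.08%. Going by the values given here, the only measured step, a number 8.9 percentage points lower from compound 1 to compound 2 (within the scatter), changes the ester end of the chain and does not separate the two compounds beyond the scatter. Compound 2 therefore stands with compound 1 as a pair of low readings that cannot be told apart on these numbers; neither can be called the weaker of the two.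

Compound 3, `O=C(O)C[C@H](NC(=O)CN(c1nc(Cl)nc2[nH]cnc12)C1CC1)C(=O)O`, differs from compound 2 by carboxymethyl in place of hydrogen on a saturated chain carbon bound to an amide-type nitrogen and a carbonyl carbon. Among the compounds with values here, no measured step touches this chain carbon; the single step in hand concerns the oxygen end of the acid and was itself within the scatter, so it offers no direction for the new change. Within the data shown here, with both measured values low and no step pointing either way, the expectation for this assay is a step of a number 0.9 percentage points higher from compound 2 to compound 3 (within the scatter), that is, nothing beyond the scatter. Compound 3 is therefore estimated at 10%, with a range from 0% to 25%.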

Compound 3, a percentage reported as activity, at one dose (the size of the read-out at that dose, not a potency): 11.6%
Beside the measured number, compound 3's estimate is 1.6 percentage points below it; low and high end bracket the measured number.
By their numbers in this assay, from the lowest: compounds 2, 3 and 1 (each within the scatter of the next).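

In this assay, the chain carbon bound to an amide-type nitrogen and a carbonyl carbon gives its first reading: carboxymethyl in place of hydrogen gives a number 2.5 percentage points higher from compound 2 to compound 3 (within the scatter) and so leaves the read-out indistinguishable from that of the unsubstituted chain. The earlier step concerned only the ester end of the chain, whereas this one shows that the chain carbon can carry carboxymethyl, turning the end of the chain into 1,2-dicarboxyethyl, without a change that can be told from the scatter. Nothing available bears on why the reading stays where it does.

As far as these compounds go, since the readings on both sides of this step are low, it remains open whether a different group on this carbon, such as methyl, benzyl or a chain ending in an amine, would move the reading beyond the scatter. Also open, from the compounds shown here alone, are the opposite arrangement at this carbon and the benzyl ester of the 1,2-dicarboxyethyl end, which would show whether the ester change behaves on this chain as it does on the unsubstituted one.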